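Triazole for Imidazole and Cytotoxicity in Macrophage Cells

The compounds below may be only part of what the source reports. "The series", "measured", "known", "first", "only" and "open" are said of these compounds alone.

Compound 1 `O=[N+]([O-])c1ccc(O[C@H]2CCc3ccccc3[C@@H]2n2ccnc2)cc1` and compound 2 `Clc1cccc(CO[C@H]2CCc3ccccc3[C@@H]2n2ccnc2)c1` both carry 1H-imidazol-1-yl on a saturated ring carbon; how their two cores differ is not broken down here. In an ADME assay on J774.A1 cells (Mus musculus) for cytotoxicity, read by MTT assay (on this read-out lower numbers stand for higher toxicity in this test and higher numbers for lower toxicity in this test), compound 1 gives 21.4 ug/mL. In this assay compound 2 gives 15.5 ug/mL, a number within the usual scatter of that for compound 1, so the two are not distinguished. Compound 3 `O=[N+]([O-])c1ccc(O[C@H]2CCc3ccccc3[C@@H]2n2ccnn2)cc1` differs from compound 1 by 1H-1,2,3-triazol-1-yl in place of 1H-imidazol-1-yl on a saturated ring carbon. For compound 3 this assay reports only a limit, > 100 ug/mL, not a number. The measured step of an at least 4.6-fold higher number from compound 1 to compound 3 (0.66 log units; beyond the scatter) is therefore open-ended, because it rests on (the limit of > 100 ug/mL in this assay, at which 1 of the 3 values shown sits), and its true size may be larger than stated.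

Compound 4 `Clc1cccc(CO[C@H]2CCc3ccccc3[C@@H]2n2ccnn2)c1` has not yet been measured. It differs from compound 2 by the same kind of change, (1H-1,2,3-triazol-1-yl in place of 1H-imidazol-1-yl on a saturated ring carbon); the surroundings differ only in wording, the ring atom next to the place bearing a group of 9 heavy atoms in compound 2 where in compound 1 it bears a large group. For compound 4 a step of at least similar size is expected, a 5.8-fold higher number from compound 2 to compound 4 (0.76 log units; beyond the scatter), because the same change gave an at least 4.6-fold higher number from compound 1 to compound 3 (0.66 log units; beyond the scatter). Compound 4 is thus estimated at 90 ug/mL, with a likely range from 40 ug/mL to 200 ug/mL; this expectation rests on a single measured pair, and this assay may again report only a limit rather than a number.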

Compound 4, half-maximal cytotoxic concentration: 30.2 ug/mL
Compound 4: the middle estimate sits 3.0-fold (0.47 log units) above what was measured, and the stated range ends above it.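

On the core of compound 2 in this assay, putting 1H-1,2,3-triazol-1-yl in place of 1H-imidazol-1-yl gives a 1.9-fold higher number from compound 2 to compound 4 (0.29 log units; within the scatter), so on this core the change cannot be separated from ordinary variation between repeated measurements. From the compounds shown here alone, this does not show that the size of the change depends on the core, and it does not show that the change carries over from one core to the other with the same size: the same change on two cores in this assay, an at least 4.6-fold higher number (0.66 log units; beyond the scatter) from compound 1 to compound 3 and a 1.9-fold higher number (0.29 log units; within the scatter) from compound 2 to compound 4; the limit leaves it open whether they differ For compound 3 the entry > 100 ug/mL is a limit and not a number, so the size of the step on the other core remains unknown.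

The compounds shown cover this swap on only two cores, leaving open how it behaves on a core carrying a different group, such as an amine or a carboxylic acid, in place of the nitro or chloro substituent. They also leave open whether another five-membered aromatic ring on the same saturated ring carbon, such as 1H-pyrazol-1-yl or 1H-tetrazol-1-yl, would read like 1H-imidazol-1-yl or like 1H-1,2,3-triazol-1-yl in this assay.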